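A Methoxy Added to a Sulfonamide Analogue

A few compounds are considered here, and "the series" means these few. Any claim that something is new, unique, unknown or untested is made for them only; others in the source may bear on it.

Compound 1, `COc1ccccc1NC(=O)N[C@@H]1C2CCN(CC2)[C@@H]1Cc1cccnc1`, gives in an assay on a protein complex for binding affinity to Neuronal acetylcholine receptor; alpha4/beta2 (Homo sapiens) (on this read-out lower numbers stand for stronger inhibition and higher numbers for weaker inhibition), only a limit, > 10000 nM.
Compound 2, `COc1ccc(NC(=O)N[C@@H]2C3CCN(CC3)[C@@H]2Cc2cccnc2)c(OC)c1`, gives in this assay only a limit, > 10000 nM.
Compound 3, `O=S(=O)(N[C@@H]1C2CCN(CC2)[C@@H]1Cc1cccnc1)c1ccccc1`, gives in this assay only a limit, > 10000 nM.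

Compounds 1 and 2 share a urea on their core; compound 3 carries a sulfonamide instead, and the difference between the two cores is not broken down here. From compound 1 to compound 2 the change is methoxy in place of hydrogen on an aromatic carbon. The step it made, a step that the two limits leave unreadable from compound 1 to compound 2, cannot be read, since both ends sit at the limit of > 10000 nM in this assay, at which 3 of the 3 values shown sit.

Compound 4, `COc1ccc(S(=O)(=O)N[C@@H]2C3CCN(CC3)[C@@H]2Cc2cccnc2)cc1`, is not yet measured. It arises from compound 3 by methoxy in place of hydrogen on an aromatic carbon. For the measured compounds named here, this is the same kind of change as the one from compound 1 to compound 2, though the surroundings differ: in compound 2 the new methoxy sits meta to a methoxy group, whereas in compound 4 no such neighbour is present.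

Going by the values given here, since the only earlier example of this change gave no readable step, and all three measured compounds sit at the limit, compound 4 is expected to stay at that limit as well, with an estimated step that the limit leaves unreadable from compound 3 to compound 4 in this assay. The estimated value for compound 4 is 12000 nM, within a range from 4000 nM to 40000 nM.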

Compound 4, inhibition constant: > 10000 nM
Compound 4: only a limit was reported (the forecaster's own chance of this, stated with the estimate: 85%); the middle value is on the limit's open side.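

Compound 4, like compound 3, gives only a limit and not a number, so no size can be read for the step between them, the change from phenyl to 4-methoxyphenyl: the limit of > 10000 nM in this assay, at which 4 of the 4 values shown sit.

The compounds shown leave open whether methoxy in place of hydrogen on an aromatic carbon changes the result in this assay at all, for either the urea compounds or the sulfonamide compounds.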